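The source may report more compounds than this note shows. Statements on the series, on what has been measured and on what is new or still open speak of the compounds shown alone.

In an ADME assay on a cell-free system (plasma, Homo sapiens) for metabolic stability, read by LC-MS (on this read-out lower numbers stand for a shorter-lived compound and higher numbers for a longer-lived compound), compound 3 (`COC(=O)c1cccc(-c2cc(C(=O)Nc3ccncc3F)ccc2CN)c1`) gives 1.08 h and lies within the scatter of compound 2 (`CCCCCOC(=O)c1cccc(-c2cc(C(=O)Nc3ccncc3)ccc2CN)c1`) at 0.967 h while compound 1 (`NCc1ccc(C(=O)Nc2ccncc2F)cc1-c1cccc(C(=O)OCC2CCCCO2)c1`) gives 0.117 h in the same read-out. Compound 4 (`COC(=O)c1cccc(-c2cc(C(=O)Nc3ccncc3)ccc2CN)c1`) comes from compound 3 by one change: hydrogen in place of fluoro on an aromatic carbon. For the measured compounds named here, the only measured step, a 9.2-fold higher number from compound 1 to compound 3 (0.97 log units; beyond the scatter) (hydrogen in place of oxan-2-yl), lies elsewhere and does not isolate this change. Compound 2 also carries hydrogen at that place and gives 0.967 h with a different chain. The expected 1.1-fold lower number from compound 3 to compound 4 (0.03 log units; within the scatter) stays within the scatter in this assay with no set direction. For compound 4 the estimated value is 1 h with an expected range from 0.45 h to 2.2 h as half-life.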

Compound 4, half-life: 1.52 h
Compound 4: middle estimate off by 1.5-fold (0.18 log units), on the low side; the measured number falls inside the stated range.
By their numbers in this assay, from the lowest: compound 1; then compounds 2, 3 and 4 (each within the scatter of the next).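

In this assay, 3-fluoropyridin-4-yl going to pyridin-4-yl with the methyl ester held fixed gives a 1.4-fold higher number from compound 3 to compound 4 (0.15 log units; within the scatter), so fluoro and hydrogen at this place cannot be told apart on this read-out. On the ester chain, hydrogen in place of butyl gives a 1.6-fold higher number from compound 2 to compound 4 (0.20 log units; within the scatter), whereas only the oxan-2-yl step, a 9.2-fold higher number from compound 1 to compound 3 (0.97 log units; beyond the scatter), lies beyond the scatter. No measurement at hand bears on the reason for these half-lives.

The compounds shown leave open whether chloro, an amine or a carboxylic acid at this place would separate from fluoro and hydrogen. On these data alone, whether fluoro counts with the oxan-2-yl ester of compound 1 also stays open.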